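A few compounds are considered here, and "the series" means these few. Any claim that something is new, unique, unknown or untested is made for them only; others in the source may bear on it.

Measured in an ADME assay on THP-1 cells (Homo sapiens) for cytotoxicity, read by MTT assay, with a stated time of 72 h; on this read-out lower numbers stand for an effect already at smaller amounts and higher numbers for an effect only at larger amounts of compound:
- compound 1 `O=c1nc(-c2ccccc2)c2cc(-c3ccccc3)ccc2[nH]1`: > 50000 nM (a limit)
- compound 2 `Cc1ccc2[nH]c(=O)nc(-c3ccccc3)c2c1`: > 50000 nM (a limit)

Neither entry is a true number, and compound 2 stands with compound 1 at the same limit of this assay: the limit of > 50000 nM in this assay, at which 2 of the 2 values shown sit. Compound 3 `O=c1nc(-c2ccccc2)c2cc(N3CCNCC3)ccc2[nH]1` keeps the core of compound 2 but carries piperazin-1-yl in place of methyl on an aromatic carbon, (piperazin-1-yl in place of methyl on an aromatic carbon).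

Among the compounds with values here, the only measured step that bears on this change is a step that the two limits leave unreadable from compound 1 to compound 2, so it offers no size to carry over. Within the data shown here, it swapped a different pair of groups at the same place, and no measured compound yet carries piperazin-1-yl. No clear step can therefore be predicted in this assay, and another limit is the likeliest result. Some allowance toward smaller amounts remains, since the new group is untested.

The expected change is an at least 1.2-fold lower number from compound 2 to compound 3 (0.09 log units; that floor lies within the scatter), an estimate with little data behind it. Compound 3 is estimated at 40000 nM. Its expected range runs from 12000 nM to 100000 nM.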

Compound 3, half-maximal effective concentration: > 25000 nM
Compound 3: only a limit was reported (the forecaster's own chance of this, stated with the estimate: 60%); the middle value does not contradict the limit.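

Within the data shown here, no step in this assay can be read from this result: compound 1, compound 2 and compound 3 are all reported only as limits, so the steps among them have no readable size. The compounds shown leave open at what concentration, if any, each of the three would reach its half-maximal effect.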